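This account rests on a few compounds, and the source may have more. Where it says the series, first, only, none or still open, it means among the compounds named here.

Compound 2 `CN(C)CCCCOC(=O)Nc1ccc(Cn2nc(-c3cccnc3)c3ccccc3c2=O)cc1` is one of three compounds tested in an ADME assay on Huh-7 cells (Homo sapiens) for cytotoxicity, read by MTT assay, with a stated time of 48 h; on this read-out lower numbers stand for higher toxicity in this test and higher numbers for lower toxicity in this test; in this assay compound 2 gives 68000 nM, the second highest of the three numbers. Its nearest neighbour is compound 3 `CN(C)CCCCOC(=O)Nc1ccc(Cn2nc(-c3ccccc3C#N)c3ccccc3c2=O)cc1`, which gives 90700 nM; the furthest is compound 1 `CN(C)CCCCN(C(=O)O)c1ccc(N2N=C(c3ccc(F)cc3)C3C=CC=CC3C2=O)cc1`, which gives 21800 nM. Compound 4 `CN(C)CCCCOC(=O)Nc1ccc(Cn2nc(-c3ccccc3C(F)(F)F)c3ccccc3c2=O)cc1` is not yet measured. It differs from compound 2 in one place: 2-(trifluoromethyl)phenyl in place of pyridin-3-yl on an aromatic carbon. For the measured compounds named here, the only measured step at this same place is a 1.3-fold higher number from compound 2 to compound 3 (0.13 log units; within the scatter), a step within the scatter, so a different group on this aromatic carbon is expected to leave the number about where it is in this assay. For compound 4 the expected step is therefore a 1.1-fold higher number from compound 2 to compound 4 (0.04 log units; within the scatter), and the estimated value is 75000 nM with a range from 35000 nM to 160000 nM.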

Compound 4, half-maximal cytotoxic concentration: 35700 nM
The estimate for compound 4 lay 2.1-fold (0.32 log units) above the measured number, and the stated range covers the measured number.
By their numbers in this assay, from the lowest: compounds 1, 4, 2 and 3 (each within the scatter of the next, the first and the last beyond it).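

Within this assay, the step of a 1.9-fold lower number from compound 2 to compound 4 (0.28 log units; within the scatter) still stays inside the usual scatter, so replacing pyridin-3-yl here has not yet given a clear change on its own. For the compounds shown here, the step of a 2.5-fold lower number from compound 3 to compound 4 (0.40 log units; beyond the scatter) is different: it is the first step at this position to pass beyond the scatter, though only modestly, and it shows that the group carried on the phenyl ring can matter. Nothing available explains this gap. Still open, as far as these compounds go, is how a plain phenyl ring, or a phenyl ring carrying an amine or a carboxylic acid, would read at this position.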